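A few compounds are considered here, and "the series" means these few. Any claim that something is new, unique, unknown or untested is made for them only; others in the source may bear on it.

Working notes on the series.

Compound 1 `CNC(=O)[C@@]12C[C@@H]1[C@@H](n1cnc3c(NCc4cccc(Cl)c4)nc(C#CCCCCc4cn(CCCCN)nn4)nc31)[C@H](O)[C@@H]2O` is the reference point here. In an assay on CHO cells for displacement of a labelled ligand from adenosine receptor A3 (Homo sapiens), read by scintillation counting (on this read-out lower numbers stand for stronger inhibition and higher numbers for weaker inhibition), compound 1 gives 47 nM, the lowest of the two numbers recorded so far. For the measured compounds named here, its only measured neighbour is compound 2 `CNC(=O)[C@@]12C[C@@H]1[C@@H](n1cnc3c(NCc4cccc(Cl)c4)nc(C#CCCCCc4cn(Cc5ccc(-n6sccc6=O)cc5)nn4)nc31)[C@H](O)[C@@H]2O`, which in this assay gives 102 nM; the step of a 2.2-fold higher number from compound 1 to compound 2 (0.34 log units; beyond the scatter) shows that enlarging the group on the triazole nitrogen from a short amine-bearing chain to a benzyl carrying an isothiazolone ring costs a modest amount of affinity.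

Compound 3 `CNC(=O)[C@@]12C[C@@H]1[C@@H](n1cnc3c(NCc4cccc(Cl)c4)nc(C#CCCCCc4cn(-c5ccc(N=C=S)cc5)nn4)nc31)[C@H](O)[C@@H]2O` is not yet measured. It differs from compound 1 as follows: a group of 9 heavy atoms (7 carbon, 1 nitrogen, 1 sulfur; one six-membered aromatic ring of carbon only) in place of a group of 5 heavy atoms (4 carbon, 1 nitrogen; no ring), on an aromatic nitrogen. The nearest comparison is the step from compound 1 to compound 2, since both replace the 4-aminobutyl with an aromatic-ring-bearing group on the same ring nitrogen, though the group entering in compound 3 is attached directly through the ring and carries an isothiocyanate rather than an isothiazolone. On that basis a modest rise in this assay is expected for compound 3, of the order seen for compound 2, as the step of a 1.9-fold higher number from compound 1 to compound 3 (0.28 log units; within the scatter).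

The estimate for compound 3 in this assay is therefore 90 nM, expected to fall between 40 nM and 220 nM.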

Compound 3, inhibition constant: 37.5 nM
The estimate for compound 3 lay 2.4-fold (0.38 log units) above the measured number, and the stated range ends above it.
By their numbers in this assay, from the lowest: compounds 3 and 1 (each within the scatter of the next); then compound 2.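

In this assay the step is a 1.3-fold lower number from compound 1 to compound 3 (0.10 log units; within the scatter), so on this aromatic nitrogen the 4-aminobutyl group can give way to the larger group with a six-membered aromatic ring and an isothiocyanate, with no difference that can be told from the scatter. The terminal amine of the 4-aminobutyl group is therefore not required to hold this level of inhibition in this pair, and the higher number of compound 2 cannot be put down simply to the presence of a six-membered aromatic ring in the group on this nitrogen, since compound 3 carries one too. Nothing on record bears on why the numbers fall as they do.

Compound 2 and compound 3 differ both in the link from the ring to the aromatic nitrogen and in the group the ring carries, so the shown compounds do not separate the two features. A plain phenyl group, or a benzyl group carrying an isothiocyanate, would be needed to tell whether the isothiocyanate, the direct attachment or neither accounts for the gap between those two compounds.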